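The compounds below may be only part of what the source reports. "The series", "measured", "known", "first", "only" and "open" are said of these compounds alone.

Compound 1 `O=C(Nc1cccc(-n2cc(-c3ccncc3)c(-c3ccc(Cl)c(O)c3)n2)c1)Nc1cccc(C(F)(F)F)c1` gives 1490 nM in a functional assay on MDA-MB-435 cells (Homo sapiens) for inhibition, read by sulforhodamine B assay, with a stated time of 48 h (on this read-out higher numbers stand for weaker inhibition and lower numbers for stronger inhibition), and stands at one end of the two numbers shown, within the scatter of its nearest neighbour. Compound 2 `O=C(Nc1cccc(-n2cc(-c3ccncc3)c(-c3ccc(Cl)c(O)c3)n2)c1)Nc1ccc(Cl)c(Cl)c1` gives 1100 nM in this assay. Within the data shown here, the one measured step, a 1.4-fold lower number from compound 1 to compound 2 (0.13 log units; within the scatter), exchanges the whole aryl group on the urea-type nitrogen. Compound 3 `O=C(Nc1cccc(-n2cc(-c3ccncc3)c(-c3ccc(Cl)c(O)c3)n2)c1)Nc1cc(C(F)(F)F)cc(C(F)(F)F)c1` differs from compound 1 by trifluoromethyl in place of hydrogen on an aromatic carbon. Among the measured compounds shown here, no measured step matches this change, and the single step available is within the scatter, so compound 3 is expected to show a 1.2-fold lower number from compound 1 to compound 3 (0.09 log units; within the scatter) in this assay, nothing beyond the scatter. Compound 3 is therefore estimated at 1200 nM, ranging from 450 nM to 3200 nM.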

Compound 3, half-maximal inhibitory concentration: 910 nM
Beside the measured number, compound 3's estimate is 1.3-fold (0.12 log units) above it; low and high end bracket the measured number.
By their numbers in this assay, from the lowest: compounds 3, 2 and 1 (each within the scatter of the next).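

Trifluoromethyl in place of hydrogen on this aromatic carbon, meta to a trifluoromethyl group, gives a 1.6-fold lower number from compound 1 to compound 3 (0.21 log units; within the scatter) in this assay. The earlier step exchanged the whole aryl group, whereas this one changes a single place on the ring of compound 1, and the number again stays within the scatter. No measurement at hand accounts for this result.

Going by these compounds, whether an amine, a carboxylic acid or a methoxy group at this position would move the number beyond the scatter remains open. So does whether any change to the shared core would do so.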